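A few compounds are considered here, and "the series" means these few. Any claim that something is new, unique, unknown or untested is made for them only; others in the source may bear on it.

Compound 2 `CC1=C(/C=C/C(=O)/C=C/c2cc(C(F)(F)F)cc(C(F)(F)F)c2)C(C)(C)CCC1O` and compound 1 `CC1=CCCC(C)(C)C1/C=C/C(=O)/C=C/c1cccc(C(F)(F)F)c1` share a common core and differ in the groups carried by their aromatic ring. In a functional assay on CWR22R cells (Homo sapiens) for cytotoxicity, read by MTT assay, with a stated time of 72 h (a higher number here means a weaker inhibitor, a lower number a stronger inhibitor), compound 2 gives 2200 nM and compound 1 gives 2900 nM; the two numbers lie within the scatter of each other, so neither can be called the stronger. Compound 3 `CC1=C(/C=C/C(=O)/C=C/c2cc(F)cc(C(F)(F)F)c2)C(C)(C)CCC1O` has not yet been measured. It differs from compound 2 by fluoro in place of trifluoromethyl on an aromatic carbon. Within the data shown here, no measured pair shows this swap, so only a small step in this assay is expected, with no clear direction. For compound 3 the estimate is 2800 nM, between 1400 nM and 6000 nM, which means an expected step of a 1.3-fold higher number from compound 2 to compound 3 (0.10 log units; within the scatter).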

Compound 3, half-maximal inhibitory concentration: 2400 nM
The estimate for compound 3 lay 1.2-fold (0.07 log units) above the measured number; the measured number falls inside the stated range.
By their numbers in this assay, from the lowest: compounds 2, 3 and 1 (each within the scatter of the next).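

In this assay, fluoro in place of trifluoromethyl on this aromatic carbon gives a 1.1-fold higher number from compound 2 to compound 3 (0.04 log units; within the scatter). Among these compounds, this is the first comparison that changes one place only, which compound 1 and compound 2 could not offer, and it shows that a group of one heavy atom and a group of four give numbers that cannot be told apart here. No measurement at hand explains this result. Still open, from the compounds shown here alone, is whether an amine or a carboxylic acid on this carbon would fit the same picture, and whether the remaining trifluoromethyl group can be exchanged just as freely.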